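The source may report more compounds than this note shows. Statements on the series, on what has been measured and on what is new or still open speak of the compounds shown alone.

Compound 1 `CC(C)CCn1nc(-c2cccs2)c(O)c(C2=NS(=O)(=O)c3cc(S(N)(=O)=O)ccc3N2)c1=O` — in an ADME assay on Huh-7 cells (Homo sapiens) for cytotoxicity, with a stated time of 72 h (on this read-out higher numbers stand for lower toxicity in this test and lower numbers for higher toxicity in this test), compound 1 gives > 33000 nM, a limit of the test rather than a number.
Compound 2 `CC(C)CCn1nc(-c2ccccc2)c(O)c(C2=NS(=O)(=O)c3cc(NS(C)(=O)=O)ccc3N2)c1=O` — in this assay compound 2 gives > 1000 nM, likewise a limit.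
Compound 3 `CC(C)CC(C)n1nc(-c2cccs2)c(O)c(C2=NS(=O)(=O)c3cc(NS(C)(=O)=O)ccc3N2)c1=O` — in this assay compound 3 gives > 33000 nM, again a limit.

Compound 3 therefore stands at the limit of > 33000 nM in this assay, at which 2 of the 3 values shown sit, and no number is known for it; compound 2 sits at the limit of > 1000 nM in this assay, at which 1 of the 3 values shown sits. Compound 4 `CS(=O)(=O)Nc1ccc2c(c1)S(=O)(=O)N=C(c1c(O)c(-c3cccs3)nn(Cc3ccccn3)c1=O)N2` has not yet been measured. It differs from compound 3 in one place: (pyridin-2-yl)methyl in place of 1,3-dimethylbutyl on an aromatic nitrogen. No measured step among these three compounds runs in one place only, so no step size can be read from them. For this assay the expected step of a number no higher from compound 3 to compound 4 (the limit leaves the size open) is none beyond the scatter, with the direction open. Compound 4 is estimated at 33000 nM, in a range of 10000 nM to 100000 nM.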

Compound 4, half-maximal cytotoxic concentration: > 1000 nM
Compound 4 was reported as a limit (the forecaster's own chance of this, stated with the estimate: 70%); the middle value does not contradict the limit.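

Compound 3 and compound 4 are both reported only as limits, so no step can be read between them. The compounds shown leave open whether (pyridin-2-yl)methyl in place of 1,3-dimethylbutyl shifts the read-out in this assay at all.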